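Aryl change on the sulfonamide nitrogen

The source may hold more compounds than are shown below. What is called first, only, known or untested is meant among the compounds shown, and "the series" means these compounds.

In a functional assay on M21 cells (Homo sapiens) for antiproliferative activity, read by sulforhodamine B assay, with a stated time of 48 h (on this read-out higher numbers stand for weaker inhibition and lower numbers for stronger inhibition), compound 1 (`Cc1ccc(NS(=O)(=O)c2ccc(N3CCNC3=O)cc2)cc1`) gives 260 nM and compound 2 (`Cc1ccc(NS(=O)(=O)c2ccc(N3CCNC3=O)cc2)c(C)c1`) gives 150 nM on the shared core. These two numbers lie within the scatter of each other, so compound 2 stands level with compound 1 on what has been measured. The change to compound 3 (`COc1ccccc1NS(=O)(=O)c1ccc(N2CCNC2=O)cc1`) is 2-methoxyphenyl in place of 2,4-dimethylphenyl on a sulfonamide nitrogen. Among the compounds with values here, the only measured step, a 1.7-fold lower number from compound 1 to compound 2 (0.24 log units; within the scatter) for methyl in place of hydrogen on an aromatic carbon, bears on this change only loosely, and no measured compound carries a methoxy group. Nothing measured sets a direction, so no step beyond the scatter is expected. The estimated move is a 1.7-fold higher number from compound 2 to compound 3 (0.22 log units; within the scatter) and no larger step is expected. The estimate for compound 3 is 250 nM with an expected range of 70 nM to 1000 nM in this series.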

Compound 3, half-maximal inhibitory concentration: 300 nM
For compound 3 the middle estimate is 1.2-fold (0.08 log units) below the measured one; the measured number falls inside the stated range.
By their numbers in this assay, from the lowest: compounds 2, 1 and 3 (each within the scatter of the next).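

Working notes on the sulfonamide nitrogen: in this assay, 2-methoxyphenyl, the only aryl group here that carries an oxygen and a hydrogen-bond acceptor, gives a 2.0-fold higher number from compound 2 to compound 3 (0.30 log units; within the scatter) and a 1.2-fold higher number from compound 1 to compound 3 (0.06 log units; within the scatter) as the two steps into this compound. Neither step lies beyond the scatter, so 4-methylphenyl, 2,4-dimethylphenyl and 2-methoxyphenyl stand level at this position, and the exchange of methyl for methoxy sets no direction in this small set. No evidence accompanies these numbers to account for the result.

From the compounds shown here alone, whether any aryl group on this nitrogen can produce a step beyond the scatter remains open. An amine, a carboxylic acid or a longer alkoxy chain on the aromatic ring could test this, as could a pyridine ring in place of the phenyl ring.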